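Trimethoxyphenyl in Place of Methoxyphenyl: an Expectation

This account rests on a few compounds, and the source may have more. Where it says the series, first, only, none or still open, it means among the compounds named here.

Three measured compounds share one core. Compound 1 `Fc1ccc(C2CC(c3ccc(Cl)cc3)=NN2c2ccc(-c3ccccc3)nn2)cc1` in a functional assay on A549 cells (Homo sapiens) for antiproliferative activity, read by MTT assay, with a stated time of 24 h (on this read-out lower numbers stand for stronger inhibition and higher numbers for weaker inhibition), gives > 100000 nM, a limit of the assay. Compound 2 `FC(F)(F)c1ccc(C2CC(c3ccc(Cl)cc3)=NN2c2ccc(-c3ccccc3)nn2)cc1` in this assay likewise reaches only the limit > 100000 nM. For the measured compounds named here, compound 3 `COc1ccc(C2CC(c3ccc(Cl)cc3)=NN2c2ccc(-c3ccccc3)nn2)cc1` in this assay gives 100000 nM, the only number among the three. Two of the three values sit at the limit (the limit of > 100000 nM in this assay, at which 2 of the 3 values shown sit). The change to compound 4 `COc1cc(C2CC(c3ccc(Cl)cc3)=NN2c2ccc(-c3ccccc3)nn2)cc(OC)c1OC` is 3,4,5-trimethoxyphenyl in place of 4-methoxyphenyl on a saturated ring carbon. Going by the values given here, no measured step carries this change; the nearest are a number no higher from compound 1 to compound 3 (the limit leaves the size open) and a number no higher from compound 2 to compound 3 (the limit leaves the size open), both left open in size by the limit. One therefore expects in this assay a step of a 2.5-fold lower number from compound 3 to compound 4 (0.40 log units; beyond the scatter) without measured precedent, and a real chance of another limit. Compound 4 is estimated at 40000 nM, between 8000 nM and 100000 nM.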

Compound 4, half-maximal inhibitory concentration: 83300 nM
Estimate against measurement, compound 4: 2.1-fold (0.32 log units) below, and the stated range covers the measured number.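

In this assay, for the compounds shown here, 3,4,5-trimethoxyphenyl in place of 4-methoxyphenyl gives the first step at this saturated ring carbon whose size can be read, a 1.2-fold lower number from compound 3 to compound 4 (0.08 log units; within the scatter), and the extra methoxy groups leave the number within the scatter. Against the other two groups only floors can be read, an at least 1.2-fold lower number from compound 2 to compound 4 (0.07 log units; that floor lies within the scatter) and an at least 1.2-fold lower number from compound 1 to compound 4 (0.07 log units; that floor lies within the scatter), since those two compounds stand at a limit: the limit of > 100000 nM in this assay, at which 2 of the 4 values shown sit. No group at this position therefore yet shows a step beyond the scatter.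

On these data alone, whether an amine or a carboxylic acid on the aromatic ring at this carbon would give such a step stays open.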